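Aryl variation on the carbonyl carbon: cytotoxicity notes

The source may report more compounds than this note shows. Statements on the series, on what has been measured and on what is new or still open speak of the compounds shown alone.

Measured compounds:
compound 1 `COc1cc(-c2cc(/C=C/C(=O)c3ccc(Cl)c(Cl)c3)[nH]n2)cc(OC)c1OC`: 103%
compound 2 `COc1ccc(C(=O)/C=C/c2cc(-c3cc(OC)c(OC)c(OC)c3)n[nH]2)cc1OC`: 107%
compound 3 `COc1ccc(C(=O)/C=C/c2cc(-c3cc(OC)c(OC)c(OC)c3)n[nH]2)cc1`: 103%

All three numbers come from a functional assay on COLO 205 cells (Homo sapiens) for cytotoxicity, read by sulforhodamine B assay, with a stated time of 48 h, tested at 0.01 uM; on this read-out lower numbers stand for a stronger effect and higher numbers for a weaker effect at the one concentration tested. Compound 3 stands level with compound 1 at the digits given, the two together forming the lowest pair of the three, and the step of a number 4 percentage points lower from compound 2 to compound 3 (within the scatter) is within the scatter, so the three compounds are not separated by this read-out.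

Compound 4 `COc1cc(-c2cc(/C=C/C(=O)c3ccc(F)c(F)c3)[nH]n2)cc(OC)c1OC` is the next member. It differs from compound 3 as follows: 3,4-difluorophenyl in place of 4-methoxyphenyl on a carbonyl carbon.

Among the measured compounds shown here, two measured steps bear on this kind of exchange on the carbonyl carbon. Replacing 3,4-dichlorophenyl with 4-methoxyphenyl gave no change at the digits printed from compound 1 to compound 3 (within the scatter), and replacing 3,4-dichlorophenyl with 3,4-dimethoxyphenyl gave a number 4 percentage points higher from compound 1 to compound 2 (within the scatter). Neither exchange of the aryl group on the carbonyl carbon moved the read-out beyond the scatter, and nothing in the set suggests a halogenated aryl group behaves differently from a methoxylated one here. The expectation for compound 4 is therefore a step of a number 1 percentage points higher from compound 3 to compound 4 (within the scatter) in this assay , that is none beyond the scatter. Compound 4 is expected to give about 104%, in the range 94% to 114%.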

Compound 4, a percentage reported as activity, at one concentration (the size of the read-out at that concentration, not a potency): 101%
For compound 4 the middle estimate is 3 percentage points above the measured one; the measured number falls inside the stated range.
By their numbers in this assay, from the lowest: compounds 4, 1, 3 and 2 (each within the scatter of the next).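

In this assay, among the compounds shown here, the steps to the new compound are a number 2 percentage points lower from compound 3 to compound 4 (within the scatter), a number 6 percentage points lower from compound 2 to compound 4 (within the scatter) and a number 2 percentage points lower from compound 1 to compound 4 (within the scatter). 3,4-Difluorophenyl on the carbonyl carbon therefore joins 3,4-dichlorophenyl, 3,4-dimethoxyphenyl and 4-methoxyphenyl without separating from any of them, and the exchange of one halogenated aryl group for another, which the earlier compounds did not include, also stays within the scatter. No supporting data bear on why this position gives the same read-out across these four aryl groups.

As far as these compounds go, with all four compounds unseparated at the single concentration tested, the read-out gives no ranking of these aryl groups, and whether they would separate at a higher concentration remains open. From the compounds shown here alone, it also remains open whether an aryl group carrying an amine or a carboxylic acid on the carbonyl carbon, or a longer chain in place of the aryl group, would move the read-out beyond the scatter.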